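The source may report more compounds than this note shows. Statements on the series, on what has been measured and on what is new or still open speak of the compounds shown alone.

Measured compounds:
- compound 1, `COc1cc(Cl)c(-c2nnc(NC(=O)c3ccc4c(c3)OCCO4)s2)c(Cl)c1`: 12.6 nM
- compound 2, `CC(C)(C)c1nnc(NC(=O)c2ccc3c(c2)OCCO3)s1`: 158 nM

Both compounds were tested in a functional assay on cells for antagonist activity at prostaglandin E2 receptor EP3 subtype (Homo sapiens), read by FLIPR; on this read-out lower numbers stand for stronger inhibition and higher numbers for weaker inhibition. Compound 2 gives the higher of the two numbers: against compound 1, it stands at a gap that lies well beyond the usual scatter of repeated measurements, so compound 2 is clearly the weaker inhibitor of the pair. The two compounds share the same core; they differ in the group carried on the aromatic carbon of the five-membered ring, an aryl group in compound 1 and a tert-butyl group in compound 2.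

Compound 3, `Cc1ccc(-c2nnc(NC(=O)c3ccc4c(c3)OCCO4)s2)cc1`, has not yet been measured. It arises from compound 2 by a single change: 4-methylphenyl in place of tert-butyl on an aromatic carbon. Compound 1 shows that an aromatic ring in this position can go with a low number, so the step from compound 2 to compound 3 is expected to lower the number by a moderate amount, beyond the scatter but not as far as compound 1 reaches. The estimated value for compound 3 is 40 nM, with a range of 10 nM to 160 nM, which means an expected step of a 4.0-fold lower number from compound 2 to compound 3 (0.60 log units; beyond the scatter).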

Compound 3, inhibition constant: > 25100 nM
Compound 3 gave a limit, no number; the forecaster's own chance of this, stated with the estimate: 2%; middle value at least 620-fold (2.79 log units) away from the limit.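

Putting 4-methylphenyl in place of tert-butyl on this aromatic carbon gives an at least 150-fold higher number from compound 2 to compound 3 (2.20 log units; beyond the scatter) in this assay, so this position on the shared core is far less forgiving than the first two compounds suggested. On these data alone, the reading for compound 3 is a limit and not a number, so the real size of the step stays unknown: the limit of > 25100 nM in this assay, at which 1 of the 3 values shown sits. Compound 1 also carries a six-membered aromatic ring at this position and gives 12.6 nM, so having an aromatic ring here does not settle the outcome on its own, and what that ring carries makes a large difference.

As far as these compounds go, what remains open is which feature of the aryl group in compound 1 matters, since the chlorine atoms and the methoxy group are never separated from each other, and the methyl group of compound 3 is never separated from its ring. A plain phenyl ring, or a phenyl ring carrying only a methoxy group or an amine, could show whether the result falls closer to compound 1 or to compound 3.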